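Trimming a Side Chain on a Weak Inhibitor

This account rests on a few compounds, and the source may have more. Where it says the series, first, only, none or still open, it means among the compounds named here.

Compound 1 `CCCCCc1ccc(NS(=O)(=O)c2ccc(N3CCNC3=O)cc2)cc1` was tested in a functional assay on MCF7 cells (Homo sapiens) for antiproliferative activity, read by sulforhodamine B assay, with a stated time of 48 h; a higher number here means a weaker inhibitor, a lower number a stronger inhibitor. Compound 1 gives only a limit here, > 1000 nM, so its exact potency is not known. Two further compounds that share the same core were measured as numbers: compound 2 `Cc1ccccc1NS(=O)(=O)c1ccc(N2CCNC2=O)cc1` gives 280 nM, and compound 3 `Cc1cc(C)cc(NS(=O)(=O)c2ccc(N3CCNC3=O)cc2)c1` gives 100 nM. For the measured compounds named here, the one measured step between them, a 2.8-fold lower number from compound 2 to compound 3 (0.45 log units; beyond the scatter), concerns the methyl groups on the phenyl on the sulfonamide nitrogen, not the chain carried by compound 1. Compound 4 `CCCCc1ccc(NS(=O)(=O)c2ccc(N3CCNC3=O)cc2)cc1` differs from compound 1 by hydrogen in place of methyl on a saturated chain carbon, four bonds along the chain from an aromatic carbon. Going by the values given here, no measured step speaks to this change directly; the only anchor is the limit of > 1000 nM in this assay, at which 1 of the 3 values shown sits. Since the change is a small one in structure, compound 4 is expected to stay near where compound 1 stands, so the step that the limit leaves unreadable from compound 1 to compound 4 is estimated to be modest. Compound 4 is therefore estimated at 1500 nM, within a range from 400 nM to 6000 nM, with a real chance that only a limit is reported again.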

Compound 4, half-maximal inhibitory concentration: 770 nM
Estimate against measurement, compound 4: 1.9-fold (0.29 log units) above; low and high end bracket the measured number.
By their numbers in this assay, from the lowest: compound 3; then compound 2; then compound 4. At a limit, above all of these: compound 1.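

Hydrogen in place of methyl at this chain carbon yields a compound that can be read as a number: in this assay compound 4 gives 770 nM. Compound 1 gives only a limit, > 1000 nM. The change therefore shows an at least 1.2-fold lower number from compound 1 to compound 4 (0.11 log units; that floor lies within the scatter), so these values do not establish a real gain in potency from this one-carbon trim, and the true size of the step cannot be read: the limit of > 1000 nM in this assay, at which 1 of the 4 values shown sits.

Still open, going by these compounds, is whether a shorter chain, such as propyl or ethyl, would move the number in this assay beyond the usual scatter. Also open, on these data alone, is what an amine or a carboxylic acid carried on this chain would do to the number in this assay.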